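A few compounds are considered here, and "the series" means these few. Any claim that something is new, unique, unknown or untested is made for them only; others in the source may bear on it.

Compound 1, `Cc1ccc(/C=C/C[C@H]2C[C@@H]([C@@H](O)c3ccccc3)CO[C@@H]2c2ccccc2)cc1C`: 10000 nM in a functional assay on HeLa cells (Homo sapiens) for cytotoxicity, read by WST assay, with a stated time of 48 h; a lower number here means a stronger inhibitor, a higher number a weaker inhibitor.
Compound 2, `COc1ccc([C@H](O)[C@H]2CO[C@H](c3ccc(OC)c(OC)c3)[C@@H](C/C=C/c3ccc(OC)c(OC)c3)C2)cc1`: 46000 nM in this assay.
Compound 3, `COc1ccc(CCC[C@H]2C[C@@H]([C@@H](O)c3ccc(OC)c(OC)c3)CO[C@@H]2c2ccc(OC)c(OC)c2)cc1OC`: 37700 nM in this assay.

Of these three, compound 1 has the lowest number in this assay, and both other values lie beyond the usual scatter above it, compound 3 being the closer of the two and compound 2 the further. All three share a core, and they differ only in the groups hung on it.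

Compound 4, `O[C@@H](c1ccccc1)[C@H]1CO[C@H](c2ccccc2)[C@@H](C/C=C/c2cccc(F)c2)C1`, is not yet measured. It differs from compound 1 in one place: 3-fluorophenyl in place of 3,4-dimethylphenyl on a double-bonded chain carbon bound to a double-bonded chain carbon. Both groups are single six-membered aromatic rings of carbon only, without donors or acceptors, so the change is modest. Among the compounds with values here, no measured pair shows this kind of change, so the expected step is small and without a clear direction, probably within the scatter. Compound 4 is therefore estimated to give 12000 nM, in the range 4000 nM to 40000 nM. This estimate corresponds to an expected 1.2-fold higher number from compound 1 to compound 4 (0.08 log units; within the scatter).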

Compound 4, half-maximal inhibitory concentration: 8380 nM
Compound 4: the middle estimate sits 1.4-fold (0.16 log units) above what was measured; the measured number falls inside the stated range.
By their numbers in this assay, from the lowest: compounds 4 and 1 (each within the scatter of the next); then compounds 3 and 2 (each within the scatter of the next).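

Within the data shown here, this is the first pair here that differs in one place: 3-fluorophenyl in place of 3,4-dimethylphenyl on a double-bonded chain carbon bound to a double-bonded chain carbon gives a 1.2-fold lower number from compound 1 to compound 4 (0.08 log units; within the scatter) in this assay. At this position, then, one aromatic carbon ring can replace the other without a change that stands out from the scatter. Nothing measured here explains this result. On these data alone, it remains open whether a phenyl ring carrying an amine or a carboxylic acid would move the number beyond the scatter. A longer chain leading to the ring is equally untested among these compounds.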